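Aryl in place of isopropyl on the ring nitrogen

The source may report more compounds than this note shows. Statements on the series, on what has been measured and on what is new or still open speak of the compounds shown alone.

Three compounds of the shared core have been run in an ADME assay on Huh-7 cells (Homo sapiens) for cytotoxicity; a lower number here means that less compound is tolerated, a higher number that more compound is tolerated. Compound 1 `Cc1ccccc1-c1nn(-c2ccc(F)cc2F)cc1CNCCN1CCCCC1` reaches only the limit of the assay, > 20000 nM, so no number is known for it. Compound 2 `Cc1ccccc1-c1nn(C(C)C)cc1CNCCN1CCN(C)CC1` likewise stops at the limit, > 20000 nM, which is a limit of the assay and not a measured number. Within the data shown here, compound 3 `CN1CCN(CCNCc2cn(-c3ccc(C(F)(F)F)cc3)nc2-c2ccc(C(F)(F)F)cc2)CC1` is the one compound with a number, 1500 nM. Among the measured compounds shown here, no two of the measured compounds differ in a single place, so no step between them is counted; what the set shows is the limit of > 20000 nM in this assay, at which 2 of the 3 values shown sit.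

Compound 4 `CSc1ccc(-n2cc(CNCCN3CCN(C)CC3)c(-c3ccccc3C)n2)cc1` is not yet measured. It differs from compound 2 by 4-(methylsulfanyl)phenyl in place of isopropyl on an aromatic nitrogen. Compound 3 carries an aryl group on the same ring nitrogen and is the member that gives a number, while compound 1 also carries an aryl group there yet sits at the limit, so an aryl group on that nitrogen alone does not settle the read-out among these three. The step from compound 2 to compound 4 is expected to be an at least 2.2-fold lower number from compound 2 to compound 4 (0.34 log units; beyond the scatter), towards a number being reached, though a limit remains possible. Compound 4 is therefore expected at 9000 nM, with a range from 3000 nM to 25000 nM.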

Compound 4, half-maximal cytotoxic concentration: 17000 nM
Beside the measured number, compound 4's estimate is 1.9-fold (0.28 log units) below it; the range from low to high includes it.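

In this assay the series now has its first pair differing in one place, and 4-(methylsulfanyl)phenyl in place of isopropyl on the aromatic nitrogen gives an at least 1.1-fold lower number from compound 2 to compound 4 (0.07 log units; that floor lies within the scatter). The floor of this step lies within the scatter, which means that a lower number is not established, although the aryl compound 4 gives a true number at this position, whereas the isopropyl compound 2 does not. The real size of the step cannot be read because compound 2 carries only a limit of the assay, not a number: the limit of > 20000 nM in this assay, at which 2 of the 4 values shown sit.

Still open, as far as these compounds go, is whether the read-out follows the aromatic ring itself or the methylsulfanyl group on it, a question that a plain phenyl or a 4-methoxyphenyl group on the same nitrogen would address. Also open, from the compounds shown here alone, is whether the change carries over to the other side chains of the series, such as a primary amine or a morpholine in place of the methylated ring amine, given that compound 1 and compound 3 differ from compound 4 in more than one place and offer no reading of it.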